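Repeating a Small Chain Change on a Larger Compound

The compounds below may be only part of what the source reports. "The series", "measured", "known", "first", "only" and "open" are said of these compounds alone.

Compound 1 `COc1ccc(-c2nc3cc(/C=C4\SC(=O)NC4=O)ccc3[nH]2)cc1OC` and compound 2 `COc1cc(-c2nc3cc(/C=C4\SC(=O)NC4=O)ccc3[nH]2)ccc1OCC(C)C` share one core and differ in a single spot: isopropyl in place of hydrogen on a saturated chain carbon bound to an oxygen on an aromatic ring. In an ADME assay on HEK-293T cells (Homo sapiens) for inhibition, read by MTT assay, with a stated time of 48 h (on this read-out higher numbers stand for weaker inhibition and lower numbers for stronger inhibition), compound 1 gives 21700 nM, and compound 2 gives 14100 nM. The step between them, a 1.5-fold lower number from compound 1 to compound 2 (0.19 log units; within the scatter), is small enough that repeated testing of either compound could easily reverse it, so the two numbers are best read as equivalent.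

Compound 3 `COc1ccc(-c2nc3cc(/C=C4\SC(=O)N(Cc5cc(OC)c(OC)c(OC)c5)C4=O)ccc3[nH]2)cc1OC` carries a much larger group on the other end of the molecule; how its core differs from the core of compound 1 is not broken down here. In this assay, among the compounds with values here, compound 3 gives 6760 nM, the lowest of the three numbers so far, and its distance from compound 2 as well as from compound 1 lies beyond the usual scatter.

Compound 4 `COc1cc(-c2nc3cc(/C=C4\SC(=O)N(Cc5cc(OC)c(OC)c(OC)c5)C4=O)ccc3[nH]2)ccc1OCC(C)C` has not yet been measured. It differs from compound 3 by isopropyl in place of hydrogen on a saturated chain carbon bound to an oxygen on an aromatic ring, the same change that separates compound 1 from compound 2, made in the same place. Because the earlier step of a 1.5-fold lower number from compound 1 to compound 2 (0.19 log units; within the scatter) stayed within the scatter, the estimated step for compound 4 is a 1.5-fold lower number from compound 3 to compound 4 (0.18 log units; within the scatter), a near-repeat of that earlier one. In this assay compound 4 is therefore expected to give about 4500 nM, with a plausible range from 2200 nM to 9500 nM.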

Compound 4, half-maximal inhibitory concentration: 6650 nM
Compound 4: middle estimate off by 1.5-fold (0.17 log units), on the low side; the measured number falls inside the stated range.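

In this assay, the swap of methoxy to isobutoxy gives a 1.0-fold lower number from compound 3 to compound 4 (0.01 log units; within the scatter), so compound 3 and compound 4 are best read as equivalent, just as compound 1 and compound 2 are on the smaller core. Set side by side, the two steps agree, which means this change carries from one core to the other without any readable difference in its outcome: the same change on two cores in this assay, a 1.5-fold lower number (0.19 log units; within the scatter) from compound 1 to compound 2 and a 1.0-fold lower number (0.01 log units; within the scatter) from compound 3 to compound 4, 1.5-fold (0.18 log units) apart, within the scatter of two such steps. This does not show that the change lowers the number on either core. Neither step can be told apart from the scatter of repeated testing. Two pairs of compounds are too few to make a rule for the whole series, and the data give no cause for the result.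

The compounds shown leave open what this assay would read with something other than methoxy or isobutoxy in this place, such as a longer chain like hexyloxy, or a chain ending in an amine or a carboxylic acid. They also leave open whether the swap of methoxy to isobutoxy would read the same on a core carrying a different group in place of the large one found in compound 3 and compound 4.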